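The compounds below may be only part of what the source reports. "The series", "measured", "known", "first", "only" and "open" are said of these compounds alone.

Measured so far:
Compound 1, `COc1cc(NC(C)CCCN2C(=O)CN(C(=O)[C@H](N)CCSC)C2(C)C)c2ncccc2c1`; in an ADME assay on A549 cells (Homo sapiens) for cytotoxicity, with a stated time of 72 h (a higher number here means a weaker inhibitor, a lower number a stronger inhibitor), compound 1 gives 7900 nM.
Compound 2, `COc1cc(NC(C)CCCN2C(=O)CN(C(=O)[C@@H](C)N)C2(C)C)c2ncccc2c1`; in this assay compound 2 gives 7800 nM.
Compound 3, `COc1cc(NC(C)CCCN2C(=O)CN(C(=O)CN)C2(C)C)c2ncccc2c1`; in this assay compound 3 reaches only a limit, > 100000 nM.

For the measured compounds named here, compound 3 stands apart from the other two: its result is a limit of the assay, not a number, and it is the one value of the three that sits at the limit of > 100000 nM in this assay, at which 1 of the 3 values shown sits. Compound 1 and compound 2 lie close together, a 1.0-fold lower number from compound 1 to compound 2 (0.01 log units; within the scatter).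

Compound 4, `COc1cc(NC(C)CCCN2C(=O)CN(C(=O)[C@H](N)C(C)C)C2(C)C)c2ncccc2c1`, is not yet measured. It differs from compound 3 by isopropyl in place of hydrogen on a saturated chain carbon bound to an amine nitrogen and a carbonyl carbon. The measured steps that bear on this are the two that go the other way at the same carbon: an at least 12-fold higher number from compound 1 to compound 3 (1.10 log units; beyond the scatter) and an at least 12-fold higher number from compound 2 to compound 3 (1.10 log units; beyond the scatter). Both were large and both lost the number when the side chain was replaced by hydrogen. Restoring a side chain, here isopropyl, is therefore expected to bring a large step back in this assay, toward a lower number, an at least 12-fold lower number from compound 3 to compound 4 (1.09 log units; beyond the scatter). Compound 4 is expected to give about 8000 nM, within the range 3000 nM to 30000 nM.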

Compound 4, half-maximal inhibitory concentration in the A549 assay: 5500 nM
Beside the measured number, compound 4's estimate is 1.5-fold (0.16 log units) above it; low and high end bracket the measured number.
By their numbers in the A549 assay, from the lowest: compounds 4, 2 and 1 (each within the scatter of the next). At a limit, above all of these: compound 3.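

In the A549 assay, isopropyl in place of methyl gives a 1.4-fold lower number from compound 2 to compound 4 (0.15 log units; within the scatter), and isopropyl in place of 2-(methylsulfanyl)ethyl gives a 1.4-fold lower number from compound 1 to compound 4 (0.16 log units; within the scatter), so a third side chain at this saturated chain carbon joins the first two within the scatter, despite their different shapes. In the A549 assay, the change from hydrogen gives an at least 18-fold lower number from compound 3 to compound 4 (1.25 log units; beyond the scatter), which leaves hydrogen as the only substituent here that stands apart. The result for compound 3 is a limit, not a number: the limit of > 100000 nM in the A549 assay, at which 1 of the 4 values shown sits.

In a physicochemical assay for lipophilicity, measured as octanol-water partition (a lower number here means a more polar compound, a higher number a more lipophilic compound), compound 3 gives 2.19, and compound 4 gives 2.93. From the compounds shown here alone, whether that gap in the A549 assay follows lipophilicity stays open, since a single pair cannot settle it: the measured partition coefficient of compound 3, 2.19, and of compound 4, 2.93, a number 0.74 log units higher (beyond the scatter). Also open, going by these compounds, is whether a side chain ending in a carboxylic acid or a second amine would sit with the three side chains or with hydrogen.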